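The source may report more compounds than this note shows. Statements on the series, on what has been measured and on what is new or still open speak of the compounds shown alone.

Among the measured compounds shown here, in a functional assay on HeLa cells (Homo sapiens) for cytotoxicity, read by sulforhodamine B assay (a lower number here means a stronger inhibitor, a higher number a weaker inhibitor), compound 2 `CC(NS(=O)(=O)c1ccc(Cl)cc1)C1=CC(=O)c2c(O)ccc(O)c2C1=O` gives 810 nM and holds the lower of the two numbers measured so far. For the measured compounds named here, compound 1 `Cc1ccc(S(=O)(=O)NC(C)C2=CC(=O)c3c(O)ccc(O)c3C2=O)cc1` stands higher at 5340 nM as the only other measured compound. Compound 3 `CC(=O)c1ccc(S(=O)(=O)NC(C)C2=CC(=O)c3c(O)ccc(O)c3C2=O)cc1` now awaits its measurement. It has acetyl in place of chloro on an aromatic carbon, para to a large group (acetyl in place of chloro on an aromatic carbon). Going by the values given here, one measured step bears on this place, the change from methyl to chloro (a 6.6-fold lower number from compound 1 to compound 2 (0.82 log units; beyond the scatter)) and it lay beyond the scatter. Among the compounds with values here, neither measured compound carries acetyl, so that step shows only that a change here can move the number. With compound 2 at 810 nM as the starting point, a modest rise in the number is expected, smaller than that one measured step. The expected step is modest (a 2.2-fold higher number from compound 2 to compound 3 (0.35 log units; beyond the scatter)) and rests on little data. Compound 3 is estimated at 1800 nM (expected range 550 nM to 5500 nM).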

Compound 3, half-maximal inhibitory concentration: 5760 nM
The estimate for compound 3 lay 3.2-fold (0.51 log units) below the measured number; the measured number lies above the stated range.
By their numbers in this assay, from the lowest: compound 2; then compounds 1 and 3 (each within the scatter of the next).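

In this assay, the change from 4-chlorophenyl to 4-acetylphenyl gives a 7.1-fold higher number from compound 2 to compound 3 (0.85 log units; beyond the scatter) and so takes back about as much as the earlier change from methyl to chloro had gained. The comparison of acetyl with methyl gives a 1.1-fold higher number from compound 1 to compound 3 (0.03 log units; within the scatter) and leaves these two groups unseparated at this position, so among the three groups shown only chloro stands apart, with the lower number. Nothing measured here explains why chloro stands apart from the other two groups.

The compounds shown leave open whether chloro's lower number is shared by another halogen such as bromine or fluorine. They also leave open how an amine or a carboxylic acid at this position would compare with compound 2 in this assay.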